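A few compounds are considered here, and "the series" means these few. Any claim that something is new, unique, unknown or untested is made for them only; others in the source may bear on it.

Compound 1 `COC(=O)c1cccc(-c2ccc(F)c(C(=O)Nc3c[nH]nc3C(=O)Nc3ccc(F)cc3)c2F)c1`: "not determined" (no result reported)
Compound 2 `O=C(Nc1ccc(F)cc1)c1n[nH]cc1NC(=O)c1c(F)ccc(-c2ccccc2)c1F`: 2370 nM

In a functional assay on A2058 cells (Homo sapiens) for antiproliferative activity, read by luminescence and CellTiter-Glo, with a stated time of 96 h (a higher number here means a weaker inhibitor, a lower number a stronger inhibitor), compound 2 gives 2370 nM. For the measured compounds named here, this is the only number available, so compound 2 cannot be ranked against another compound, and compound 1 has no result to compare.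

Compound 3 `Nc1ccc(-c2ccc(F)c(C(=O)Nc3c[nH]nc3C(=O)Nc3ccc(F)cc3)c2F)cn1` keeps the core of compound 2 but carries 6-aminopyridin-3-yl in place of phenyl on an aromatic carbon. That carbon lies ortho to one fluoro group and para to another. Going by the values given here, no measured pair shows how large a change at this position can be, so any expectation rests on the structural change alone and remains uncertain. A step towards a stronger inhibitor, beyond the usual scatter, is expected, with an estimated 7.9-fold lower number from compound 2 to compound 3 (0.90 log units; beyond the scatter). For compound 3 the expected value is 300 nM, within an estimated range of 50 nM to 1800 nM.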

Compound 3, half-maximal inhibitory concentration: 8540 nM
Estimate against measurement, compound 3: 28-fold (1.45 log units) below, outside the stated range (above it).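

In this assay, for the compounds shown here, putting 6-aminopyridin-3-yl in place of phenyl gives a 3.6-fold higher number from compound 2 to compound 3 (0.56 log units; beyond the scatter), the first measured change at this carbon, ortho to one fluoro group and para to another. The step is modest but beyond the scatter, so this position is not indifferent to the group it carries, and here the move is towards a weaker inhibitor. Nothing among the data shown accounts for this shift.

From the compounds shown here alone, whether the ring nitrogen or the amine carries the step remains open, and a pyridin-3-yl or a 4-aminophenyl group at this carbon would separate the two. Going by these compounds, compound 1 has no result, so the effect of its methyl ester cannot be read, and it is unknown how a carboxylic acid there would behave.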